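Chloromethylbenzyl purines: amino substitution on the core

This account rests on a few compounds, and the source may have more. Where it says the series, first, only, none or still open, it means among the compounds named here.

The series pairs a chloromethylbenzyl arm with a chlorinated purine-type core. Compound 1 `ClCc1cccc(Cn2cnc3c(Cl)ncnc32)c1` is the reference here; in a functional assay on RPMI-8226 cells (Homo sapiens) for cytotoxicity, read by sulforhodamine B assay, with a stated time of 48 h (a higher number here means that more compound is tolerated, a lower number that less compound is tolerated), compound 1 gives 87100 nM. Compound 2 `ClCc1ccc(Cn2cnc3nc(Cl)nc(Cl)c32)cc1` carries a second chloro group on the core, and in this assay compound 2 gives 97700 nM. The two numbers lie within the scatter of each other, so neither compound can be set apart from the other; compound 1 simply holds the lower of the two figures. Compound 3 `ClCc1ccc(Cn2cnc3c(Cl)nc(Cl)nc32)cc1` is the isomer of compound 2 in the arrangement of the core chloro groups; in this assay compound 3 gives "not determined" (no result reported), so no number is at hand for it.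

The next compound, compound 4 `Nc1nc(Cl)c2ncn(Cc3cccc(CCl)c3)c2n1`, differs from compound 1 by amino in place of hydrogen on an aromatic carbon. Going by the values given here, no measured pair shows a change of this kind, so there is no step to lean on. With both measured values sitting close together at the high end, the expectation for compound 4 is a step that stays within the scatter, in either direction. Compound 4 is expected to give about 80000 nM, within 30000 nM to 200000 nM. The step from compound 1 to compound 4 is thus estimated as a 1.1-fold lower number from compound 1 to compound 4 (0.04 log units; within the scatter).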

Compound 4, concentration lethal to 50% of the cells: > 100000 nM
Compound 4 was reported as a limit (the forecaster's own chance of this, stated with the estimate: 20%); middle value at least 1.2-fold (0.09 log units) away from the limit.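

Amino in place of hydrogen on an aromatic carbon, between two ring nitrogen atoms, is the first change on the core of compound 1 that can be read as a step. In this assay compound 4 gives > 100000 nM as a limit of the assay, not a number. The step reads an at least 1.1-fold higher number from compound 1 to compound 4 (0.05 log units; that floor lies within the scatter) and so shows no drop in the number at this position, but the size of any rise cannot be read because the value is a limit: the limit of > 100000 nM in this assay, at which 1 of the 4 values shown sits.

Still open, from the compounds shown here alone, is whether a methylamino group, a dimethylamino group or a hydroxyl group at this same position would bring the number down to a measurable value. Also open, going by these compounds, is whether amino at this position behaves the same way on a core carrying a second chloro group.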